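Compound 2 to compound 4: a 4-cyanophenyl exchange

A few compounds are considered here, and "the series" means these few. Any claim that something is new, unique, unknown or untested is made for them only; others in the source may bear on it.

Measured in a physicochemical assay for lipophilicity, read by HPLC, at pH 7.4; a lower number here means a more polar compound, a higher number a more lipophilic compound:
- compound 1 `COc1cc(-c2cc(-c3ccc(S(C)(=O)=O)cc3)cnc2N)ccc1O`: 1.9
- compound 2 `COc1ccc(-c2cc(-c3ccc(S(C)(=O)=O)cc3)cnc2N)cn1`: 2.2
- compound 3 `Cc1ccc(-c2cc(-c3ccc(S(C)(=O)=O)cc3)cnc2N)cn1`: 1.8

Not yet measured: compound 4 `CS(=O)(=O)c1ccc(-c2cnc(N)c(-c3ccc(C#N)cc3)c2)cc1`.

Compound 2 stands at 2.2. This lies within the scatter of compound 1 and beyond the scatter of compound 3. The change now in view is 4-cyanophenyl in place of 6-methoxypyridin-3-yl on an aromatic carbon, with 4-cyanophenyl in place of 6-methoxypyridin-3-yl, ortho to an amino group. Going by the values given here, only one measured step bears on it, and only loosely: a number 0.40 log units lower from compound 2 to compound 3 (beyond the scatter), a modest step beyond the scatter, with methyl in place of methoxy. That step replaces only the methoxy of the 6-methoxypyridin-3-yl group, whereas here the whole group leaves. Among the compounds with values here, no measured compound carries a nitrile, so the data give no direction in this assay. A step smaller than that modest one is expected. The estimated step is no change at the digits printed from compound 2 to compound 4 (within the scatter), none beyond the scatter. For compound 4 the expected value is 2.2, with an estimated range from 1.8 to 2.6.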

Compound 4, distribution coefficient: 2.4
Estimate against measurement, compound 4: 0.20 log units below; low and high end bracket the measured number.
By their numbers in this assay, from the lowest: compounds 3, 1, 2 and 4 (each within the scatter of the next, the first and the last beyond it).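

At this position, ortho to an amino group, the whole aromatic group can be exchanged and not only its substituent: in this assay, 4-cyanophenyl in place of 6-methoxypyridin-3-yl gives a number 0.20 log units higher from compound 2 to compound 4 (within the scatter). Set against 6-methylpyridin-3-yl, the same 4-cyanophenyl gives a number 0.60 log units higher from compound 3 to compound 4 (beyond the scatter), so the size of this exchange depends on which group leaves, and the series now has its first nitrile reading. Nothing on hand accounts for either step.

Open, on these data alone, is where a carboxylic acid or an amine in place of the nitrile of compound 4 would stand in this assay. Also open, as far as these compounds go, is what the nitrile alone contributes, for which a plain phenyl group at this position would be the comparison.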